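From butyl to cyclohexyl in a cytotoxicity series

This account rests on a few compounds, and the source may have more. Where it says the series, first, only, none or still open, it means among the compounds named here.

Going by the values given here, in a functional assay on CAL-27 cells (Homo sapiens) for cytotoxicity, read by MTT assay, with a stated time of 72 h (on this read-out higher numbers stand for weaker inhibition and lower numbers for stronger inhibition), compound 1 (`CCCCNC(=O)CN(CCCCCC(=O)NO)C(=O)c1ccc(N(C)C)cc1`) gives 1870 nM as the lower of the two numbers so far, and compound 2 (`O=C(CCCCCN(C(=O)c1ccccc1)C1(C(=O)NC2CCCCC2)CCCCC1)NO`) gives 44100 nM on the same scale. Compound 3 (`CN(C)c1ccc(C(=O)N(CCCCCC(=O)NO)CC(=O)NC2CCCCC2)cc1`), not yet measured, carries cyclohexyl in place of butyl on an amide-type nitrogen. Among the compounds with values here, no measured pair isolates this change, so in this assay no step beyond the scatter is expected, and the estimated step is a 1.2-fold higher number from compound 1 to compound 3 (0.07 log units; within the scatter) at most a slight rise. For compound 3 the expected value is 2200 nM with an estimated range from 800 nM to 6500 nM as its bounds.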

Compound 3, half-maximal inhibitory concentration: 2970 nM
Estimate against measurement, compound 3: 1.4-fold (0.13 log units) below, and the stated range covers the measured number.
By their numbers in this assay, from the lowest: compounds 1 and 3 (each within the scatter of the next); then compound 2.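

In this assay, cyclohexyl in place of butyl on the amide-type nitrogen gives a 1.6-fold higher number from compound 1 to compound 3 (0.20 log units; within the scatter). Going by these compounds alone, this is the first measured pair to isolate the change, and it shows that this position accepts a six-membered non-aromatic ring of carbon only in place of the butyl chain with no step beyond the scatter. No measurement shown gives a reason for this result. Going by these compounds, whether a phenyl ring, a longer chain or an amine at this position would also stay within the scatter remains open.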